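Oxazole sulfonamides: hydroxy to trifluoromethyl, two cores

The compounds below may be only part of what the source reports. "The series", "measured", "known", "first", "only" and "open" are said of these compounds alone.

Measured so far in an assay on isolated protein for inhibition of malate dehydrogenase, mitochondrial (Sus scrofa), with stated times of 45 min and 30 min; a higher number here means a weaker inhibitor, a lower number a stronger inhibitor:
- compound 1 `O=S(=O)(Nc1ccc(-c2nc3ccccc3o2)cc1)c1ccccc1O`: > 63000 nM, a limit of the assay, not a number.
- compound 2 `O=S(=O)(Nc1ccc2oc(-c3ccccc3)nc2c1)c1ccccc1O`: > 63000 nM, likewise a limit.
- compound 3 `O=S(=O)(Nc1ccc(-c2nc3ccccc3o2)cc1)c1ccccc1C(F)(F)F`: > 63000 nM, likewise a limit.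

Compound 1 and compound 2 share their atoms but join them differently; the difference between the two cores is not broken down here. From compound 1 to compound 3 the change is trifluoromethyl in place of hydroxy on an aromatic carbon; the step that the two limits leave unreadable from compound 1 to compound 3 is unreadable, since both sit at the limit (the limit of > 63000 nM in this assay, at which 3 of the 3 values shown sit). Compound 4 `O=S(=O)(Nc1ccc2oc(-c3ccccc3)nc2c1)c1ccccc1C(F)(F)F`, not yet measured, carries the same change on the core of compound 2: trifluoromethyl in place of hydroxy on an aromatic carbon. The step that the limit leaves unreadable from compound 2 to compound 4 is expected to be unreadable as well, resting on compound 1 to compound 3 a step that the two limits leave unreadable from compound 1 to compound 3. Compound 4 is estimated at 80000 nM in this assay, most likely reported only as a limit.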

Compound 4, half-maximal inhibitory concentration: > 63000 nM
Compound 4 ended at the assay's limit (the forecaster's own chance of this, stated with the estimate: 90%); the middle value does not contradict the limit.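

No step can be read between compound 2 and compound 4, as both values are limits and not numbers: the limit of > 63000 nM in this assay, at which 4 of the 4 values shown sit.

The compounds shown leave open how the two cores and the hydroxy and trifluoromethyl groups rank.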